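The source may report more compounds than this note shows. Statements on the series, on what has been measured and on what is new or still open speak of the compounds shown alone.

Measured so far in a physicochemical assay for metabolic stability, read by spectrophotometry, in phosphate buffer, at 25 degrees C, at pH 7.3; a lower number here means that the compound disappears faster, a higher number that the compound lasts longer
Compound 1 `CCOC(=O)c1cn(C(=O)c2cccc(C)c2)c2ncccc12`: 3.5 h
Compound 2 `Cc1cccc(C(=O)n2cc([N+](=O)[O-])c3cccnc32)c1`: 0.4 h

Compound 2, at 0.4 h as the lower of the two numbers, is the starting point. Going on to compound 3 `Cc1cccc(C(=O)n2cc(-c3nc(C)no3)c3cccnc32)c1` brings 3-methyl-1,2,4-oxadiazol-5-yl in place of nitro on an aromatic carbon as the only change. Within the data shown here, the one measured step that bears on this is an 8.8-fold lower number from compound 1 to compound 2 (0.94 log units; beyond the scatter) where nitro took the place of ethoxycarbonyl. Among the measured compounds shown here, no measured compound carries 3-methyl-1,2,4-oxadiazol-5-yl, so the guide is indirect. With nitro leaving, a rise of similar size in this assay is expected, estimated as a 6.3-fold higher number from compound 2 to compound 3 (0.80 log units; beyond the scatter) on that single step. Compound 3 is estimated at 2.5 h with an expected range of 0.9 h to 7 h for the measurement.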

Compound 3, half-life: 2.4 h
The estimate for compound 3 lay 1.0-fold (0.02 log units) above the measured number; low and high end bracket the measured number.
By their numbers in this assay, from the lowest: compound 2; then compounds 3 and 1 (each within the scatter of the next).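

In this assay, 3-methyl-1,2,4-oxadiazol-5-yl in place of nitro on this aromatic carbon gives a 6.0-fold higher number from compound 2 to compound 3 (0.78 log units; beyond the scatter), so among the groups shown the low number stays with nitro alone. In place of ethoxycarbonyl, the same group gives a 1.5-fold lower number from compound 1 to compound 3 (0.16 log units; within the scatter), so these two groups cannot be told apart in this assay. Nothing at hand gives a reason for either step. As far as these compounds go, whether an amine or a carboxylic acid on this carbon would fall with nitro or stand with the other two groups remains open.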